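Replacing a fluorophenyl amide substituent with a methylbenzyl group

The source may report more compounds than this note shows. Statements on the series, on what has been measured and on what is new or still open speak of the compounds shown alone.

Compound 2 `COc1cc(-c2nnc(SCC(=O)Nc3ccccc3F)n2N)cc(OC)c1OC` carries the only number shown: in a functional assay on HepG2 cells (Homo sapiens) for antiproliferative activity, read by MTT assay, with a stated time of 48 h (on this read-out lower numbers stand for stronger inhibition and higher numbers for weaker inhibition), compound 2 gives 18700 nM. For compound 1 `COc1cc(-c2nnc(SCC(=O)c3ccc(C(F)(F)F)cc3)n2N)cc(OC)c1OC` the result in this assay is > 100000 nM, a limit of the assay rather than a number, namely (the limit of > 100000 nM in this assay, at which 1 of the 2 values shown sits). Among the measured compounds shown here, the single measured step, an at least 5.3-fold lower number from compound 1 to compound 2 (0.72 log units; beyond the scatter), concerns the substituent on the carbonyl carbon, not the amide nitrogen. Compound 3 `COc1cc(-c2nnc(SCC(=O)NCc3ccc(C)cc3)n2N)cc(OC)c1OC` differs from compound 2 by 4-methylbenzyl in place of 2-fluorophenyl on an amide-type nitrogen. For the measured compounds named here, no measured step bears on this change, so no shift beyond the scatter is expected in this assay. Compound 3 is therefore expected to give 20000 nM, between 7000 nM and 60000 nM. That expectation amounts to a 1.1-fold higher number from compound 2 to compound 3 (0.03 log units; within the scatter).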

Compound 3, half-maximal inhibitory concentration: > 100000 nM
Compound 3 ended at the assay's limit; the forecaster's own chance of this, stated with the estimate: 15%; at least 5.0-fold (0.69 log units) between middle value and limit.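

On an amide-type nitrogen, 4-methylbenzyl in place of 2-fluorophenyl brings an at least 5.3-fold higher number from compound 2 to compound 3 (0.72 log units; beyond the scatter) in this assay, so this position does respond to the change. The result for compound 3 is a limit of the assay, not a number, and compound 2 alone keeps a measured value among the three: the limit of > 100000 nM in this assay, at which 2 of the 3 values shown sit. Compound 1 and compound 3 both stand at limits, so the step between them cannot be read.

Still open, from the compounds shown here alone, is which part of the exchange carries the loss. A plain phenyl or a 2-fluorobenzyl group on that nitrogen would separate the fluorine from the longer benzyl link.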